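The compounds below may be only part of what the source reports. "The series", "measured", "known", "first", "only" and "open" are said of these compounds alone.

Measured in a physicochemical assay for solubility, read by HPLC, at pH 7.4 (on this read-out lower numbers stand for lower solubility and higher numbers for higher solubility), so far:
- Compound 1 `CCCCC#Cc1c(C)[nH]c2ccc(Cl)cc2c1=O` gives 2000 nM
- Compound 2 `COc1cc2[nH]c(C)c(C)c(=O)c2cc1Cl` gives 5000 nM

Compound 2 holds the higher of these two numbers, and its gap to compound 1 lies beyond the usual scatter. Compound 3 `CCCCC#Cc1c(C)[nH]c2cc(OC)c(Cl)cc2c1=O` carries hex-1-yn-1-yl in place of methyl on an aromatic carbon of compound 2. Among the compounds with values here, no measured pair isolates this change. The expectation therefore leans on compound 1, which also bears hex-1-yn-1-yl and stands at 2000 nM in this assay on the shared scale. A fall beyond the scatter is expected, an estimated 5.0-fold lower number from compound 2 to compound 3 (0.70 log units; beyond the scatter) in all. Compound 3 is estimated at 1000 nM within a range of 300 nM to 3000 nM as its expected span.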

Compound 3, solubility: > 20000 nM
Compound 3 ended at the assay's limit (the forecaster's own chance of this, stated with the estimate: 10%); at least 20-fold (1.30 log units) between middle value and limit.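

In this assay, hex-1-yn-1-yl in place of methyl on an aromatic carbon gives an at least 4.0-fold higher number from compound 2 to compound 3 (0.60 log units; beyond the scatter), while methoxy in place of hydrogen on an aromatic carbon gives an at least 10-fold higher number from compound 1 to compound 3 (1.00 log units; beyond the scatter). Compound 1 alone had tied hex-1-yn-1-yl to a low number, but with methoxy also on the core the same chain goes with a higher one. The value of compound 3 is a limit of the assay, not a number, so both steps give only minimum sizes: the limit of > 20000 nM in this assay, at which 1 of the 3 values shown sits.

The compounds shown leave open how a shorter propyl chain or an amine on this aromatic carbon would read.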